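The compounds below may be only part of what the source reports. "The series", "measured", "known", "first", "only" and "open" are said of these compounds alone.

Compound 2 `CN(C)CCC(OC(=O)Nc1ccc(Oc2ccccc2)cc1)c1ccc(Cl)cc1` is the weaker of the two compounds measured in an assay on NIH3T3 cells with Urotensin-2 receptor (Homo sapiens) as the target; a lower number here means a smaller maximal response, a higher number a larger maximal response: compound 2 gives 107%, while compound 1 `COc1ccc(NC(=O)OC(CCN(C)C)c2ccc(Cl)cc2)cc1` gives 170%. Within the data shown here, the only measured step is a number 63 percentage points lower from compound 1 to compound 2 (beyond the scatter), which came from putting phenyl in place of methyl on an oxygen on an aromatic ring.

Compound 3 `CN(C)CCC(OC(=O)Nc1ccc(C(C)(C)C)cc1)c1ccc(Cl)cc1` has not yet been measured. It differs from compound 2 in one way: tert-butyl in place of phenoxy on an aromatic carbon. Among the measured compounds shown here, no measured step covers this exchange, so the one known step offers only indirect guidance. That step shows that a large change at this part of the molecule moved the maximal response a long way, so a sizeable shift is plausible, though its direction is uncertain. Compound 3 is therefore expected to give 130% in this assay, within a wide range from 80% to 190%, meaning an estimated step of a number 23 percentage points higher from compound 2 to compound 3 (beyond the scatter).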

Compound 3, largest response reached (reported as efficacy), in percent of the reference or control that the assay uses: 105%
The estimate for compound 3 lay 25 percentage points above the measured number; low and high end bracket the measured number.
By their numbers in this assay, from the lowest: compounds 3 and 2 (each within the scatter of the next); then compound 1.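

In this assay, tert-butyl in place of phenoxy gives a number 2 percentage points lower from compound 2 to compound 3 (within the scatter) even though the entering group has no ring, no oxygen and fewer heavy atoms, so this read-out does not separate these two quite different groups on the aromatic ring. Tert-butyl in place of methoxy gives a number 65 percentage points lower from compound 1 to compound 3 (beyond the scatter) and so, among these three compounds, methoxy alone stands apart, while an oxygen on the aromatic ring is not enough by itself to give the high response, as phenoxy in compound 2 shows. Nothing available explains this difference.

Going by these compounds, it remains open whether the high response needs methoxy itself or would also appear with ethoxy, hydroxyl or an amine at this position. On these data alone, how such groups would behave with other changes to the shared core also remains open.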